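The compounds below may be only part of what the source reports. "The series", "measured", "known", "first", "only" and "open" are said of these compounds alone.

Compound 1 `O=c1c(SC(=S)N2CCCCC2)coc2ccccc12`: 5800 nM
Compound 2 `O=c1cc(CSC(=S)N2CCCC2)oc2ccccc12`: 9100 nM
Compound 3 `O=c1cc(CSC(=S)N2CCCC2)oc2cc(Cl)ccc12`: > 40000 nM

Of the compounds shown here, three have been measured in a functional assay on HEp-2 cells (Homo sapiens) for antiproliferative activity, read by MTT assay, with a stated time of 72 h; a higher number here means a weaker inhibitor, a lower number a stronger inhibitor. Compound 1 gives 5800 nM and compound 2 gives 9100 nM; the two numbers lie within the scatter of each other, so no order between them is claimed. The two share the same atoms joined differently, and the difference between their cores is not broken down here. For compound 3 the result is a limit of the assay, > 40000 nM, and not a number. The change from compound 2 to compound 3 is chloro in place of hydrogen on an aromatic carbon, and it gave an at least 4.3-fold higher number from compound 2 to compound 3 (0.64 log units; beyond the scatter).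

Compound 4 `O=c1c(SC(=S)N2CCCCC2)coc2ccc(Cl)cc12` is not yet measured. Among the compounds with values here, it differs from compound 1 by chloro in place of hydrogen on an aromatic carbon, the same change as the one measured from compound 2 to compound 3. The step from compound 1 to compound 4 is therefore expected to be of a similar size, a 4.3-fold higher number from compound 1 to compound 4 (0.63 log units; beyond the scatter), resting on compound 2 at 9100 nM and the step of an at least 4.3-fold higher number from compound 2 to compound 3 (0.64 log units; beyond the scatter). Compound 4 is accordingly estimated at 25000 nM in this assay, with a range from 10000 nM to 60000 nM.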

Compound 4, half-maximal inhibitory concentration: 12200 nM
The estimate for compound 4 lay 2.0-fold (0.31 log units) above the measured number; low and high end bracket the measured number.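

In this assay, chloro in place of hydrogen on an aromatic carbon of the core of compound 1 gave a 2.1-fold higher number from compound 1 to compound 4 (0.32 log units; beyond the scatter), so on both cores shown the change moved the number the same way, towards a weaker inhibitor: the same change on two cores in this assay, an at least 4.3-fold higher number (0.64 log units; beyond the scatter) from compound 2 to compound 3 and a 2.1-fold higher number (0.32 log units; beyond the scatter) from compound 1 to compound 4; the limit leaves it open whether they differ This shows that the direction of the change carried over from one core to the other in these two pairs, though two pairs alone set no rule for the series. It does not show that the size carried over, since the step to compound 3 rests on a limit and not on a number: the limit of > 40000 nM in this assay, at which 1 of the 4 values shown sits.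

The compounds shown leave open whether a methoxy group or an amine on the same aromatic carbon would move the number as chloro does. They also leave open whether the direction seen with chloro would hold on any core other than these two.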